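Replacing ethyl with ethoxycarbonyl: an estimate for compound 4

A few compounds are considered here, and "the series" means these few. Any claim that something is new, unique, unknown or untested is made for them only; others in the source may bear on it.

Measured in a functional assay (trachea, Rattus norvegicus, strain Wistar); on this read-out lower numbers stand for an effect already at smaller amounts and higher numbers for an effect only at larger amounts of compound:
Compound 1 `CCOC(=O)COc1ccc2ccc(=O)oc2c1`: "not determined" (no result reported)
Compound 2 `CCOc1ccc2c(C)cc(=O)oc2c1`: 80000 nM
Compound 3 `CCCOc1ccc2c(C)cc(=O)oc2c1`: 267000 nM

Compound 3 holds the highest of the two numbers, with compound 2 as its nearest neighbour. Compound 4 `CCOC(=O)COc1ccc2c(C)cc(=O)oc2c1` differs from compound 3 by ethoxycarbonyl in place of ethyl on a saturated chain carbon bound to an oxygen on an aromatic ring. Going by the values given here, one measured step touches the same chain: a 3.3-fold higher number from compound 2 to compound 3 (0.52 log units; beyond the scatter), a modest change beyond the scatter. It involves only methyl in place of hydrogen, so it is a weak guide. Compound 1 also carries ethoxycarbonyl but gave no result. A step of similar modest size is therefore expected in this assay, tentatively towards a lower number. The expected step is a 2.2-fold lower number from compound 3 to compound 4 (0.35 log units; beyond the scatter). The estimate for compound 4 is 120000 nM, with an expected range of 30000 nM to 400000 nM.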

Compound 4, half-maximal effective concentration: 200000 nM
Estimate against measurement, compound 4: 1.7-fold (0.22 log units) below; low and high end bracket the measured number.
By their numbers in this assay, from the lowest: compound 2; then compounds 4 and 3 (each within the scatter of the next).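

In this assay, the step of a 1.3-fold lower number from compound 3 to compound 4 (0.13 log units; within the scatter) stays within the scatter, so a larger group carrying hydrogen-bond acceptors can replace ethyl at this saturated chain carbon without a measurable shift from the propyl compound. The step of a 2.5-fold higher number from compound 2 to compound 4 (0.40 log units; beyond the scatter) lies beyond the scatter, which leaves compound 2 with the lowest number of the three measured compounds.

As far as these compounds go, whether a carboxylic acid or an amine at the end of this chain would give a lower number remains open. Nothing given here explains why these numbers fall as they do.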